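A Methyl Group Added to a Thromboxane Synthase Inhibitor

The source may hold more compounds than are shown below. What is called first, only, known or untested is meant among the compounds shown, and "the series" means these compounds.

Three compounds that share a carboxylic acid and an imidazole-bearing arm were tested in an assay for inhibition of Thromboxane-A synthase (Homo sapiens); on this read-out lower numbers stand for stronger inhibition and higher numbers for weaker inhibition. Compound 1 `O=C(O)c1cc2cc(Cn3ccnc3)ccc2s1` gives 21 nM. The core of compound 2 `O=C(O)c1cc2ccc(Cn3ccnc3)cc2s1` differs from that of compound 1 in a way not broken down here. In this assay compound 2 gives 18 nM. Compound 3 `Cc1c(C(=O)O)sc2ccc(Cn3ccnc3)cc12` gives 29 nM. The change from compound 1 to compound 3 is methyl in place of hydrogen on an aromatic carbon, and it made a 1.4-fold higher number from compound 1 to compound 3 (0.14 log units; within the scatter). Compound 4 `Cc1c(C(=O)O)sc2cc(Cn3ccnc3)ccc12` has not been measured; it arises from compound 2 by the same change, (methyl in place of hydrogen on an aromatic carbon), at the same place. In this assay compound 4 is expected to show a 1.4-fold higher number from compound 2 to compound 4 (0.14 log units; within the scatter). That expectation rests on the earlier step of a 1.4-fold higher number from compound 1 to compound 3 (0.14 log units; within the scatter), which stayed within the scatter. Compound 4 is therefore estimated at 25 nM, most likely between 12 nM and 55 nM.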

Compound 4, half-maximal inhibitory concentration: 5.2 nM
Compound 4: the middle estimate sits 4.8-fold (0.68 log units) above what was measured, outside the stated range (below it).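

Adding the methyl group to the second core gave a 3.5-fold lower number from compound 2 to compound 4 (0.54 log units; beyond the scatter) in this assay, a step beyond the scatter. The same change therefore did not carry over unchanged from one core to the other: the same change on two cores in this assay, a 1.4-fold higher number (0.14 log units; within the scatter) from compound 1 to compound 3 and a 3.5-fold lower number (0.54 log units; beyond the scatter) from compound 2 to compound 4, 4.8-fold (0.68 log units) apart, beyond the scatter of two such steps This shows that, for these two cores, the step measured on one was a poor guide to the step on the other, but it does not show why they differ, and a single pair on each core sets no rule for other cores or groups.

As far as these compounds go, it remains open whether an ethyl group in the same place would behave as the methyl does in compound 3 or as it does in compound 4. From the compounds shown here alone, it is also open how either core would respond if an amide stood in place of the carboxylic acid.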